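A few compounds are considered here, and "the series" means these few. Any claim that something is new, unique, unknown or untested is made for them only; others in the source may bear on it.

Of the compounds shown here, three sharing one core have been tested in a functional assay on NCI-H460 cells (Homo sapiens) for cytotoxicity, read by MTT assay, with a stated time of 72 h; on this read-out lower numbers stand for stronger inhibition and higher numbers for weaker inhibition. Compound 1 `COc1ccc(OC)c(/C=N/NC(=O)Nc2ccc(Oc3ccnc(-c4nncn4CCN(C)C)c3)c(F)c2)c1` gives 2930 nM, and compound 2 `COc1cc(/C=N/NC(=O)Nc2ccc(Oc3ccnc(-c4nncn4CCN(C)C)c3)c(F)c2)cc(OC)c1OC` gives 2770 nM; between these two the step of a 1.1-fold lower number from compound 1 to compound 2 (0.02 log units; within the scatter) is small. Among the measured compounds shown here, compound 3 `CN(C)CCn1cnnc1-c1cc(Oc2ccc(NC(=O)N/N=C/c3c(O)ccc4ccccc34)cc2F)ccn1` gives 890 nM, the lowest of the three numbers and the only compound whose steps to both others lie beyond the scatter, so it is the strongest of the measured set. Compound 4 `Cc1cc(/C=N/NC(=O)Nc2ccc(Oc3ccnc(-c4nncn4CCN(C)C)c3)c(F)c2)cc(C)c1O` has not yet been measured. It differs from compound 3 in one place: 4-hydroxy-3,5-dimethylphenyl in place of 2-hydroxynaphthalen-1-yl on a carbon with a double bond to nitrogen. For the measured compounds named here, the steps that bear on this change are a 3.3-fold lower number from compound 1 to compound 3 (0.52 log units; beyond the scatter) and a 3.1-fold lower number from compound 2 to compound 3 (0.49 log units; beyond the scatter); both show that replacing a methoxy-bearing phenyl with the 2-hydroxynaphthalen-1-yl group lowered the number by a modest amount. Compound 4 moves back to a single six-membered ring, and its number is therefore expected to rise in this assay, by a step of a 2.0-fold higher number from compound 3 to compound 4 (0.31 log units; beyond the scatter), landing between compound 3 and compounds 1 and 2. The estimate for compound 4 is 1800 nM, with a range from 800 nM to 4000 nM.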

Compound 4, half-maximal inhibitory concentration: 2010 nM
Estimate against measurement, compound 4: 1.1-fold (0.05 log units) below; the measured number falls inside the stated range.
By their numbers in this assay, from the lowest: compound 3; then compounds 4, 2 and 1 (each within the scatter of the next).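

In this assay, the single-ring 4-hydroxy-3,5-dimethylphenyl does not keep the low number of the two-ring 2-hydroxynaphthalen-1-yl, as shown by a 2.3-fold higher number from compound 3 to compound 4 (0.35 log units; beyond the scatter) on this carbon with a double bond to nitrogen. Against the methoxy-bearing rings, the same group gives a 1.4-fold lower number from compound 2 to compound 4 (0.14 log units; within the scatter) and a 1.5-fold lower number from compound 1 to compound 4 (0.16 log units; within the scatter), so compound 4 cannot be told apart from compounds 1 and 2, and a hydroxyl on one ring is not enough to match compound 3. Compound 3 now stands as the strongest of the four, its steps to all the others lying beyond the scatter.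

Going by these compounds, whether the second ring or the place of the hydroxyl matters more stays open, and naphthalen-1-yl without a hydroxyl, or with an amine in its stead, would separate the two. No supporting measurement explains these differences.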